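A few compounds are considered here, and "the series" means these few. Any claim that something is new, unique, unknown or untested is made for them only; others in the source may bear on it.

Measured in a functional assay on DU-145 cells (Homo sapiens) for antiproliferative activity, read by MTT assay, with a stated time of 24 h; a lower number here means a stronger inhibitor, a higher number a weaker inhibitor:
- Compound 1 `COc1ccc(-c2noc(-c3ccncc3)n2)cc1OC1CCCC1`: > 1000000 nM (a limit)
- Compound 2 `COc1ccc(-c2noc(C3CCCN3)n2)cc1OC1CCCC1`: 242000 nM
- Compound 3 `COc1ccc(-c2noc(-c3cccnc3)n2)cc1OC1CCCC1`: > 1000000 nM (a limit)

Compound 3 has no number, only the limit > 1000000 nM. This is the limit of > 1000000 nM in this assay, at which 2 of the 3 values shown sit. Compound 4 `COc1ccc(-c2noc(-c3ccc(O)cc3)n2)cc1OC1CCCC1` carries 4-hydroxyphenyl in place of pyridin-3-yl on an aromatic carbon. Three measured steps change that same group. Two are readable, an at least 4.1-fold lower number from compound 1 to compound 2 (0.61 log units; beyond the scatter) and an at least 4.1-fold higher number from compound 2 to compound 3 (0.61 log units; beyond the scatter), and both turn on the pyrrolidin-2-yl of compound 2. The third, a step that the two limits leave unreadable from compound 1 to compound 3, gives no size. None involves a hydroxyphenyl, so only a modest step towards a lower number is expected, and compound 4 may well stay at the limit. The expected change is an at least 2.8-fold lower number from compound 3 to compound 4 (0.45 log units; beyond the scatter). For compound 4 the estimate is 350000 nM, with an expected range from 100000 nM to 1000000 nM.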

Compound 4, half-maximal inhibitory concentration: 780 nM
Estimate against measurement, compound 4: 450-fold (2.65 log units) above, and the stated range ends above it.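

In this assay, for the compounds shown here, the group at this position can shift the read-out far more than the earlier compounds showed: 4-hydroxyphenyl gives an at least 1200-fold lower number from compound 3 to compound 4 (3.10 log units; beyond the scatter) and an at least 1200-fold lower number from compound 1 to compound 4 (3.10 log units; beyond the scatter) against the two pyridinyl groups. Going by these compounds alone, it also gives a 310-fold lower number from compound 2 to compound 4 (2.49 log units; beyond the scatter) against pyrrolidin-2-yl, the only earlier group with a measured number. Compound 1 and compound 3 each stand only at a limit, so the steps from them are lower bounds: the limit of > 1000000 nM in this assay, at which 2 of the 4 values shown sit.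

The compounds shown leave open whether the hydroxyl or the carbon-only ring carries the step. A plain phenyl or a 4-methoxyphenyl at this position would separate the two.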